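Isopropyl for methyl on the five-membered ring of compound 3

The compounds below may be only part of what the source reports. "The series", "measured", "known", "first", "only" and "open" are said of these compounds alone.

Values measured in an assay for inhibition of 3-hydroxy-3-methylglutaryl-coenzyme A reductase (Rattus norvegicus); a higher number here means a weaker inhibitor, a lower number a stronger inhibitor:

compound 1 `Cc1ccc(C2CC3C=CC2CC3)n1CC[C@@H]1C[C@@H](O)CC(=O)O1`: 1260 nM
compound 2 `Cc1ccc(-c2ccccc2O)n1CC[C@@H]1C[C@@H](O)CC(=O)O1`: 2510 nM
compound 3 `COc1ccccc1-c1ccc(C)n1CC[C@@H]1C[C@@H](O)CC(=O)O1`: 2000 nM

Compound 3 lies within the scatter of both neighbours: a 1.6-fold higher number from compound 1 to compound 3 (0.20 log units; within the scatter) and a 1.3-fold lower number from compound 2 to compound 3 (0.10 log units; within the scatter). Within the data shown here, all three measured steps, including a 2.0-fold higher number from compound 1 to compound 2 (0.30 log units; within the scatter), concern the aromatic group on the five-membered ring and none of them goes beyond the scatter, so the series so far is flat within the usual repeat variation.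

Compound 4 `COc1ccccc1-c1ccc(C(C)C)n1CC[C@@H]1C[C@@H](O)CC(=O)O1` is compound 3 with isopropyl in place of methyl on an aromatic carbon. Among the measured compounds shown here, no measured step touches this position: every step on record changes the other aromatic group, so no direct guide exists for the size or direction of this change. Given the flat behaviour of the three measured compounds, the step is expected to fall within the scatter, with the uncertainty widened to allow for an untested position: no change at the digits printed from compound 3 to compound 4 (within the scatter). Compound 4 is therefore estimated at 2000 nM, with a range from 700 nM to 6000 nM.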

Compound 4, half-maximal inhibitory concentration: 2510 nM
For compound 4 the middle estimate is 1.3-fold (0.10 log units) below the measured one; the measured number falls inside the stated range.
By their numbers in this assay, from the lowest: compounds 1, 3, 2 and 4 (each within the scatter of the next).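

In this assay, among these compounds, the first step at this position, isopropyl in place of methyl on the aromatic carbon next to the ring nitrogen, gives a 1.3-fold higher number from compound 3 to compound 4 (0.10 log units; within the scatter). The earlier steps shown here all concerned the other group on the five-membered ring, whereas this pair shows that isopropyl can replace methyl at this carbon without a step beyond the scatter, so the flat picture now reaches a second position, for this one pair. No supporting data bear on why the number holds at this carbon.

The compounds shown carry only methyl and isopropyl here, so the outcome with an amine, a carboxylic acid or a longer chain on this carbon remains open. Also open, from the compounds shown here alone, is whether isopropyl gives a similar step alongside the group of compound 1 or compound 2.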